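This account rests on a few compounds, and the source may have more. Where it says the series, first, only, none or still open, it means among the compounds named here.

Measured so far:
compound 1, `CCc1nc(Cl)ncc1C(=O)Nc1cc(C(F)(F)F)cc(C(F)(F)F)c1`: 400 nM
compound 2, `Cc1nc(C(F)(F)F)ncc1C(=O)Nc1cc(C(F)(F)F)cc(C(F)(F)F)c1`: > 10000 nM

Compound 1 pairs an ethyl group with a chloro group on the shared core. Among the compounds with values here, in an assay on Jurkat cells for activation of nuclear factor NF-kappa-B complex (Homo sapiens) (a lower number here means a stronger inhibitor, a higher number a weaker inhibitor), compound 1 gives 400 nM, the only full number among the values shown. Compound 2 differs from compound 1 in more than one place, so the two are not linked by a single step. In this assay compound 2 reaches only a limit of the assay, > 10000 nM, which is the limit of > 10000 nM in this assay, at which 1 of the 2 values shown sits.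

Compound 3, `O=C(Nc1cc(C(F)(F)F)cc(C(F)(F)F)c1)c1cnc(Cl)nc1C(F)(F)F`, is not yet measured. It differs from compound 1 by trifluoromethyl in place of ethyl on an aromatic carbon. Within the data shown here, no measured pair shows this change on its own, so the size of the step has to be judged without a direct precedent. Among the measured compounds shown here, the only further value, that of compound 2, is a limit, and compound 2 also carries a different group where compound 1 has chloro, so it gives at most a faint hint.

The expectation is a step from compound 1 to compound 3 toward weaker inhibition, likely beyond the scatter but not by a great deal: a 3.8-fold higher number from compound 1 to compound 3 (0.57 log units; beyond the scatter). Compound 3 is therefore estimated at 1500 nM in this assay, with a range from 300 nM to 8000 nM.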

Compound 3, half-maximal inhibitory concentration: 50 nM
For compound 3 the middle estimate is 30-fold (1.48 log units) above the measured one, outside the stated range (below it).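

In this assay, putting trifluoromethyl in place of ethyl on this aromatic carbon, next to the ring nitrogen, gives an 8.0-fold lower number from compound 1 to compound 3 (0.90 log units; beyond the scatter), a move toward stronger inhibition that lies beyond the usual scatter. Within the data shown here, this is the first reading of this position on its own, as compound 1 and compound 2 differ in more than one place, and it shows that the position tolerates a group of 4 heavy atoms in place of one of 2 heavy atoms, with the inhibition improving rather than being lost. No measurement shown here gives a reason for this step.

A single pair cannot say whether the gain belongs to trifluoromethyl alone or whether a longer chain such as propyl, a methoxy group or an amine at the same position would do as well. Compound 2 reaches only a limit of the assay, > 10000 nM, and it differs from compound 3 in more than one place, leaving open what any group other than chloro does at the place where compound 3 carries chloro.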